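The source may hold more compounds than are shown below. What is called first, only, known or untested is meant among the compounds shown, and "the series" means these compounds.

Working notes on the series. Compound 1 `C[C@@H](NCC1CCN(CCCc2c[nH]c3ccc(-n4cnnc4)cc23)CC1)c1ccccc1` is the reference point. In an assay on CHO cells for displacement of a labelled ligand from 5-hydroxytryptamine receptor 1B (Homo sapiens) (a lower number here means a stronger inhibitor, a higher number a weaker inhibitor), compound 1 gives 14 nM, the lowest of the three numbers; compound 3 `CC(C)=CCN(C)C1CCN(CCCc2c[nH]c3ccc(-n4cnnc4)cc23)CC1` gives 41 nM and compound 2 `c1ccc(C2CCCCN2C2CCN(CCCc3c[nH]c4ccc(-n5cnnc5)cc34)CC2)cc1` gives 410 nM. Compound 4 `c1cncc(CNC2CCN(CCCc3c[nH]c4ccc(-n5cnnc5)cc34)CC2)c1` is not yet measured and differs from compound 1 in one place: ((pyridin-3-yl)methyl)amino in place of ((1-phenylethyl)amino)methyl on a saturated ring carbon. For the measured compounds named here, the one measured step that bears on this, a 2.9-fold higher number from compound 1 to compound 3 (0.47 log units; beyond the scatter), likewise exchanged the ((1-phenylethyl)amino)methyl for an amino group on the saturated ring carbon; compound 2, with a different group at that carbon, sits far higher still. A modest weakening beyond the scatter is therefore expected, a 2.9-fold higher number from compound 1 to compound 4 (0.46 log units; beyond the scatter). Compound 4 is estimated at 40 nM, with a range of 12 nM to 130 nM.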

Compound 4, half-maximal inhibitory concentration: 140 nM
Estimate against measurement, compound 4: 3.5-fold (0.54 log units) below, and the stated range ends below it.
By their numbers in this assay, from the lowest: compound 1; then compound 3; then compound 4; then compound 2.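

In this assay, ((pyridin-3-yl)methyl)amino in place of ((1-phenylethyl)amino)methyl on the saturated ring carbon gives a larger loss than the earlier exchange, with a 10-fold higher number from compound 1 to compound 4 (1.00 log units; beyond the scatter). An aromatic ring in the entering group does not keep the number low here: the non-aromatic methyl(3-methylbut-2-en-1-yl)amino of compound 3 stays lower, with a 3.4-fold higher number from compound 3 to compound 4 (0.53 log units; beyond the scatter). No measurement gives a reason for this loss.

The ring, the linker and the stereocentre all change at once in compound 4, so their shares remain unseparated. As far as these compounds go, how a benzylamino group at this carbon would read remains open.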